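This account rests on a few compounds, and the source may have more. Where it says the series, first, only, none or still open, it means among the compounds named here.

Compound 1 `CCn1ccc(N2C[C@H](CO)OC2=O)c1` is measured in an assay for inhibition of Amine oxidase [flavin-containing] B (Bos taurus), read by fluorescence, with a stated time of 30 min (a higher number here means a weaker inhibitor, a lower number a stronger inhibitor), where compound 1 gives 300 nM. That is the lowest of the three numbers at hand. Compound 2 `C=CCn1ccc(N2C[C@H](CO)OC2=O)c1` gives 625000 nM, and compound 3 `COC[C@H]1CN(c2ccn(C)c2)C(=O)O1` gives 170000 nM. The one single-point step among these, a 2100-fold higher number from compound 1 to compound 2 (3.32 log units; beyond the scatter), touches only the group on the ring nitrogen. Compound 3 differs from compound 1 in two places at once, so its value alone shows that a methoxymethyl chain paired with a methyl on the ring nitrogen sits far above compound 1.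

Compound 4 `CCn1ccc(N2C[C@H](CNC)OC2=O)c1` is not yet measured. Against compound 1 the change is methylamino in place of hydroxy on a saturated chain carbon bound to a saturated ring carbon, on the chain attached to the saturated ring. Among the measured compounds shown here, no measured step reaches this chain directly; the one step known sits elsewhere. The expectation for compound 4 is therefore drawn cautiously: compound 4 is estimated to land at 3000 nM, within 500 nM to 20000 nM. This estimate means the step of a 10-fold higher number from compound 1 to compound 4 (1.00 log units; beyond the scatter) is expected to be a loss beyond the scatter, but far smaller than the step seen from compound 1 to compound 2.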

Compound 4, inhibition constant: 18000 nM
Beside the measured number, compound 4's estimate is 6.0-fold (0.78 log units) below it; the range from low to high includes it.
By their numbers in this assay, from the lowest: compound 1; then compound 4; then compound 3; then compound 2.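

Among the compounds shown here, this is the first measured change on the chain attached to the saturated ring, and it shows that this place is sensitive in this assay: methylamino in place of hydroxy gives a 60-fold higher number from compound 1 to compound 4 (1.78 log units; beyond the scatter) on the core of compound 1. The change leaves the computed counts of hydrogen-bond donors, hydrogen-bond acceptors and net charge as they were, and methylamino brings 2 heavy atoms where hydroxy has 1, so those counts alone do not tell the two groups apart. No measurement at hand explains the rise in the number.

Still open, going by these compounds, is whether the loss follows from the nitrogen or from its added methyl. A plain amino group and a dimethylamino group, each on a saturated chain carbon bound to a saturated ring carbon, would help to separate these two readings.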